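The compounds below may be only part of what the source reports. "The series", "measured", "known", "first", "only" and "open" are said of these compounds alone.

Measured so far:
- Compound 1, `Cc1cc(Cl)cc(-c2c(C)nn(-c3nc(-c4ccc(Cl)c(Cl)c4)c(SC(C)C)s3)c2C(=O)O)c1`: 663 nM
- Compound 2, `Cc1cc(-c2c(C)nn(-c3nc(-c4ccc(Cl)c(Cl)c4)c(SC(C)C)s3)c2C(=O)O)cc(C)n1`: 580 nM

Of the compounds shown here, two have been measured in a functional assay on BJAB cells (Homo sapiens) for antiproliferative activity, with a stated time of 4 days; on this read-out lower numbers stand for an effect already at smaller amounts and higher numbers for an effect only at larger amounts of compound. Compound 1 gives 663 nM and compound 2 gives 580 nM; the change between them, a 1.1-fold lower number from compound 1 to compound 2 (0.06 log units; within the scatter), is within the scatter, so the two numbers cannot be told apart. Compound 2 holds the lower of the two numbers, but only by a margin that repeated measurements would easily blur.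

Compound 3, `Cc1nn(-c2nc(-c3ccc(Cl)c(Cl)c3)c(SC(C)C)s2)c(C(=O)O)c1-c1cccnc1`, has not yet been measured. It differs from compound 2 in one place: pyridin-3-yl in place of 2,6-dimethylpyridin-4-yl on an aromatic carbon. For the measured compounds named here, the only step on record at this position is the one from compound 1 to compound 2, which swapped one aromatic ring for another without a change beyond the scatter. That suggests the core tolerates different six-membered aromatic rings here, although a single step is thin evidence, and the ring entering here is smaller than the one leaving.

Compound 3 is therefore expected to give about 800 nM in this assay, with a plausible range from 300 nM to 2500 nM. For compound 3 the estimated step comes out as a 1.4-fold higher number from compound 2 to compound 3 (0.14 log units; within the scatter), a change not expected to exceed the scatter.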

Compound 3, half-maximal effective concentration: 12000 nM
Beside the measured number, compound 3's estimate is 15-fold (1.18 log units) below it; the measured number lies above the stated range.
By their numbers in this assay, from the lowest: compounds 2 and 1 (each within the scatter of the next); then compound 3.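

In this assay, this position proves far less forgiving than the first two compounds suggested: the change to pyridin-3-yl gives a 21-fold higher number from compound 2 to compound 3 (1.32 log units; beyond the scatter), and measured against the chlorinated phenyl ring it gives an 18-fold higher number from compound 1 to compound 3 (1.26 log units; beyond the scatter). The two rings that share the lower numbers each carry two substituents, a chlorine and a methyl on 3-chloro-5-methylphenyl and two methyls on 2,6-dimethylpyridin-4-yl, whereas pyridin-3-yl carries none and has 6 heavy atoms against the 8 of the 2,6-dimethylpyridin-4-yl it replaces; across three compounds this is only an observation, not a rule. Nothing measured here accounts for the large loss.

From compound 2 to compound 3, the methyl groups disappear and the ring also changes from a pyridin-4-yl to a pyridin-3-yl attachment, so the compounds shown cannot say which of these two changes matters. A plain pyridin-4-yl ring without methyl groups, or a pyridin-3-yl ring bearing methyl groups, would separate the two.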